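A few compounds are considered here, and "the series" means these few. Any claim that something is new, unique, unknown or untested is made for them only; others in the source may bear on it.

Measured compounds:
- compound 1, `O=C(Nc1ccccc1C(F)(F)F)C1CCc2ccccc2N1C(=O)c1ccccc1`: 6500 nM
- compound 2, `O=C(Nc1ccccc1O)C1CCc2ccccc2N1C(=O)c1ccccc1`: 3830 nM

Within the data shown here, in a functional assay on HCT-15 cells (Homo sapiens) for cytotoxicity, read by sulforhodamine B assay, with a stated time of 72 h (on this read-out lower numbers stand for stronger inhibition of growth and higher numbers for weaker inhibition of growth), compound 2 stands with the lowest of the two numbers, but its only neighbour is compound 1, and the step of a 1.7-fold lower number from compound 1 to compound 2 (0.23 log units; within the scatter) lies within the scatter, so the two compounds cannot be told apart.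

Compound 3, `O=C(Nc1ccccc1O)C1CCc2ccccc2N1C(=O)c1cccc(Cl)c1`, differs from compound 2 by chloro in place of hydrogen on an aromatic carbon, on an aromatic carbon of a six-membered aromatic ring of carbon only, meta to a large group. Among the measured compounds shown here, no measured step touches this part of the shared core: the single step known alters a different ring, and it was within the scatter. There is therefore no ground for expecting a shift beyond the scatter in this assay in either direction, and the estimate for compound 3 is a step of a 1.1-fold lower number from compound 2 to compound 3 (0.04 log units; within the scatter). Compound 3 is thus expected near 3500 nM, with a range from 1200 nM to 10000 nM.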

Compound 3, concentration for 50% growth inhibition: 23100 nM
Compound 3: middle estimate off by 6.6-fold (0.82 log units), on the low side, and the stated range ends below it.
By their numbers in this assay, from the lowest: compounds 2 and 1 (each within the scatter of the next); then compound 3.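

In this assay, the benzoyl ring of the shared core proves sensitive: a single chloro in place of hydrogen, on an aromatic carbon meta to a large group, gives a 6.0-fold higher number from compound 2 to compound 3 (0.78 log units; beyond the scatter). Among these compounds, this is the only step so far that lies beyond the scatter, and it weakens growth inhibition, whereas the change on the other ring, a 1.7-fold lower number from compound 1 to compound 2 (0.23 log units; within the scatter), could not be told from noise. No measurement here accounts for the loss seen with the chloro group.

Among the compounds shown here, with only one substituent on this ring, it remains open whether the loss is particular to chloro or would also appear with another group at the same place, such as fluoro, methoxy or an amine. As far as these compounds go, it is equally open whether chloro on another carbon of the ring would give a similar result.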